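Two aryl hydrazides at the assay limit and beyond

This account rests on a few compounds, and the source may have more. Where it says the series, first, only, none or still open, it means among the compounds named here.

In a functional assay on A549 cells (Homo sapiens) for antiproliferative activity, read by MTT assay, with a stated time of 24 h (a lower number here means a stronger inhibitor, a higher number a weaker inhibitor), compound 1 `O=C(NNc1ccccc1Cl)c1cccc(NS(=O)(=O)c2cnc(O)nc2O)c1` gives 1460 nM. Compound 2 `Cc1cccc(NNC(=O)c2ccccc2NS(=O)(=O)c2cnc(O)nc2O)c1` differs from compound 1 in more than one place. In this assay compound 2 is reported only as a limit of the assay, > 20000 nM, so its true value is not known (the limit of > 20000 nM in this assay, at which 1 of the 2 values shown sits). Compound 3 `O=C(NNC(=O)c1ccccc1NS(=O)(=O)c1cnc(O)nc1O)c1ccccc1F` has not yet been measured. It differs from compound 2 in one place: (2-fluorophenyl)carbonyl in place of 3-methylphenyl on an amine nitrogen. Within the data shown here, with compound 2 standing at the limit, there is no measured step to lean on, and the change from 3-methylphenyl to (2-fluorophenyl)carbonyl on the amine nitrogen is a large one. The expected step of an at least 1.3-fold lower number from compound 2 to compound 3 (0.12 log units; that floor lies within the scatter) is therefore uncertain, with some room for compound 3 to come in below the limit. The estimate for compound 3 in this assay is 15000 nM, within a range from 4000 nM to 40000 nM.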

Compound 3, half-maximal inhibitory concentration: 7150 nM
Compound 3: middle estimate off by 2.1-fold (0.32 log units), on the high side; low and high end bracket the measured number.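

In this assay, among these compounds, putting (2-fluorophenyl)carbonyl in place of 3-methylphenyl on the amine nitrogen gives an at least 2.7-fold lower number from compound 2 to compound 3 (0.44 log units; beyond the scatter), the first step at this position that can be read, and it lies beyond the usual scatter. Compound 2 is reported only as a limit of the assay, > 20000 nM. The step is therefore a floor and not a measured distance, and the true gap may be larger, because one end of it rests on a limit: the limit of > 20000 nM in this assay, at which 1 of the 3 values shown sits.

The carbonyl and the fluorine enter together, so the compounds shown do not separate what each contributes to the change. As far as these compounds go, how a phenylcarbonyl group without the fluorine, or a 2-fluorophenyl group without the carbonyl, would read on this nitrogen remains open.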